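Compound 1 and a change to its benzyl group

This account rests on a few compounds, and the source may have more. Where it says the series, first, only, none or still open, it means among the compounds named here.

Compound 1 `COc1ccc(N2C(=O)N(Cc3ccc(F)cc3Cl)c3ccccc3S2(=O)=O)cc1OC` was tested in an assay on isolated protein for displacement of a labelled ligand from Orexin/Hypocretin receptor type 1 (Homo sapiens), with a stated time of 90 min; on this read-out higher numbers stand for weaker inhibition and lower numbers for stronger inhibition. In this assay compound 1 gives only a limit, > 2510 nM, not a measured number. Compound 2 `COc1cc(F)c(CN2C(=O)N(c3ccc(OC)c(OC)c3)S(=O)(=O)c3ccccc32)c(Cl)c1` carries a different group on the saturated chain carbon bound to the ring nitrogen, and in this assay compound 2 gives 0.398 nM. Compound 3 `COc1cc(N2C(=O)N(Cc3c(F)cc(F)cc3F)c3ccccc3S2(=O)=O)ccn1` in this assay gives 398 nM, a number that sits between the others without a single-point step to either of them.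

Going by the values given here, the only measured step that bears on the change studied here is an at least 6300-fold lower number from compound 1 to compound 2 (3.79 log units; beyond the scatter); its exact size is uncertain because compound 1 sits at the limit of > 2510 nM in this assay, at which 1 of the 3 values shown sits.

Compound 4 `COc1ccc(N2C(=O)N(Cc3c(F)cc(C)cc3Cl)c3ccccc3S2(=O)=O)cc1OC` differs from compound 1 by 2-chloro-6-fluoro-4-methylphenyl in place of 2-chloro-4-fluorophenyl on a saturated chain carbon bound to an amide-type nitrogen in a ring. This mirrors the change to compound 2 except that a methyl stands where compound 2 has a methoxy group. A large drop in this assay is therefore expected, as an at least 1600-fold lower number from compound 1 to compound 4 (3.22 log units; beyond the scatter). The estimated value for compound 4 in this assay is 1.5 nM, with a range from 0.2 nM to 15 nM.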

Compound 4, inhibition constant: 6.31 nM
Compound 4: middle estimate off by 4.2-fold (0.62 log units), on the low side, within the range that was stated.
By their numbers in this assay, from the lowest: compound 2; then compound 4; then compound 3. At a limit, above all of these: compound 1.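

With a methyl group in place of the methoxy group of compound 2, the change on the benzyl group still gives an at least 390-fold lower number from compound 1 to compound 4 (2.59 log units; beyond the scatter), so the large gain does not depend on the methoxy group alone. The group on that aromatic carbon still matters, though: methyl in place of methoxy gives a 16-fold higher number from compound 2 to compound 4 (1.20 log units; beyond the scatter). The exact size of the gain from the 2-chloro-6-fluoro-4-methylbenzyl change remains uncertain, since compound 1 gives only a limit: the limit of > 2510 nM in this assay, at which 1 of the 4 values shown sits.

The compounds shown leave open how much of the gain belongs to the added fluorine and how much to the added methyl or methoxy group. On these data alone, it is also open how an ethoxy group or an amine would compare with methyl and methoxy on the same aromatic carbon.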